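The compounds below may be only part of what the source reports. "The series", "measured", "known", "first", "only" and "open" are said of these compounds alone.

Compound 1 `Brc1ccccc1COc1nc2ccccc2s1`: in a functional assay on the whole organism with Mus musculus as the target, with a stated time of 1 h, at a dose of 100 mg/kg by the intraperitoneal route (on this read-out lower numbers stand for less inhibition and higher numbers for more inhibition at the one dose given (going by the name of the read-out)), compound 1 gives 75.6%.
Compound 2 `c1ccc(COc2nc3ccccc3s2)cc1`: in this assay compound 2 gives 68.8%.

Compound 2 holds the lower of these two numbers, yet its gap to compound 1, a number 6.8 percentage points lower from compound 1 to compound 2 (within the scatter), stays within the scatter, so the two cannot be told apart. Compound 3 `Fc1ccccc1COc1nc2ccccc2s1` differs from compound 2 by fluoro in place of hydrogen on an aromatic carbon. Among the compounds with values here, the one measured step that bears on this, the exchange of a halogen for hydrogen on the same aromatic carbon, moved the read-out by a number 6.8 percentage points lower from compound 1 to compound 2 (within the scatter), within the scatter. For compound 3 in this assay, a step of a number 3.2 percentage points higher from compound 2 to compound 3 (within the scatter) is therefore expected, nothing beyond the scatter. The estimate for compound 3 is 72%, expected to fall between 58% and 84%.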

Compound 3, a percentage reported as inhibition, in the whole organism at one dose (the size of the read-out at that dose, not a potency): 74.6%
Beside the measured number, compound 3's estimate is 2.6 percentage points below it, within the range that was stated.
By their numbers in this assay, from the lowest: compounds 2, 3 and 1 (each within the scatter of the next).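

At this place, on an aromatic carbon ortho to a large group, fluoro in place of hydrogen gives a number 5.8 percentage points higher from compound 2 to compound 3 (within the scatter), and fluoro in place of bromo gives a number 1 percentage points lower from compound 1 to compound 3 (within the scatter). With a second halogen now in hand, hydrogen, fluoro and bromo at this position cannot be told apart in this assay. Nothing available explains this result.

Going by these compounds, it remains open whether an amine or a carboxylic acid on this aromatic carbon would move the read-out beyond the scatter. The same holds for a methoxy group placed there.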